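From methyl to methoxy on compound 1

The source may hold more compounds than are shown below. What is called first, only, known or untested is meant among the compounds shown, and "the series" means these compounds.

Going by the values given here, in an in vitro ADME assay on microsomes from liver (Homo sapiens) for metabolic stability, with a stated time of 15 min (a higher number here means faster removal of the compound, a lower number slower removal), compound 1 `COCc1cc(OC)c(-c2cccc3c(N(CC4CCOCC4)CC4CC4)c(C)nn23)c(OC)c1` gives 110 mL.min-1.g-1 as the lowest of the two numbers measured so far. Compound 2 `CCc1nn2c(-c3c(C)cc(C)cc3OC)cccc2c1N(CC1CC1)CC1CCCO1` gives 1230 mL.min-1.g-1 and stands beyond the scatter from that number. Compound 3 `COCc1cc(OC)c(-c2cccc3c(N(CC4CCOCC4)CC4CC4)c(OC)nn23)c(OC)c1` differs from compound 1 in one place (methoxy in place of methyl on an aromatic carbon) with methoxy in place of methyl on an aromatic carbon. Among the compounds with values here, no measured pair shows this change. In this assay the expected step (a 1.2-fold higher number from compound 1 to compound 3 (0.07 log units; within the scatter)) is small, slightly upward and within the scatter. Compound 3 is expected at 130 mL.min-1.g-1 (estimated range 60 mL.min-1.g-1 to 300 mL.min-1.g-1).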

Compound 3, intrinsic clearance in microsomes: 760 mL.min-1.g-1
The estimate for compound 3 lay 5.8-fold (0.77 log units) below the measured number; measured number above the stated range.
By their numbers in this assay, from the lowest: compound 1; then compounds 3 and 2 (each within the scatter of the next).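

In this assay, methoxy in place of methyl on this aromatic carbon gives a 6.9-fold higher number from compound 1 to compound 3 (0.84 log units; beyond the scatter). This first measured pair for the change shows that, on the core of compound 1, the read-out responds to what sits at this position, and that the change raises the number rather than leaving it within the scatter. No evidence is available on what lies behind this step. On these data alone, whether ethyl, an amine or a nitrile at the same carbon would move the number the same way stays open, as does whether the step holds on another core.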